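This account rests on a few compounds, and the source may have more. Where it says the series, first, only, none or still open, it means among the compounds named here.

In a physicochemical assay for lipophilicity, measured as octanol-water partition (a lower number here means a more polar compound, a higher number a more lipophilic compound), compound 1 (`O=C(NNc1ccnc2cc(Cl)ccc12)c1ccccc1/N=C/c1ccc(Cl)cc1Cl`) gives 6.22 and stands level with compound 2 (`O=C(NNc1ccnc2cc(Cl)ccc12)c1ccccc1/N=C/c1ccc(Cl)c(Cl)c1`), which gives 6.22 as well. Together they hold the top of the three numbers, while compound 3 (`O=C(NNc1ccnc2cc(Cl)ccc12)c1ccccc1/N=C/c1ccc([N+](=O)[O-])cc1`) gives 4.58 and sits well under them. Compound 4 (`N#Cc1ccc(/C=N/c2ccccc2C(=O)NNc2ccnc3cc(Cl)ccc23)cc1`) is still unmeasured and differs from compound 1 in one place (4-cyanophenyl in place of 2,4-dichlorophenyl on a carbon with a double bond to nitrogen), with 4-cyanophenyl in place of 2,4-dichlorophenyl on a carbon with a double bond to nitrogen. Two measured steps guide the expectation. Exchanging 2,4-dichlorophenyl for 3,4-dichlorophenyl showed no change at the digits printed from compound 1 to compound 2 (within the scatter) and keeps both chlorine atoms, so it says little here. Exchanging it for 4-nitrophenyl, which like 4-cyanophenyl carries no chlorine, showed a number 1.64 log units lower from compound 1 to compound 3 (beyond the scatter) and is the closer model. Nothing measured separates 4-cyanophenyl from 4-nitrophenyl, so a large fall of similar size is expected in this assay for compound 4. The estimated step is a number 1.82 log units lower from compound 1 to compound 4 (beyond the scatter) on this reading. For compound 4 the expected value is 4.4 with a range between 3.9 and 4.9 as a working estimate.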

Compound 4, partition coefficient: 4.83
Compound 4: the middle estimate sits 0.43 log units below what was measured; the range from low to high includes it.
By their numbers in this assay, from the lowest: compounds 3 and 4 (each within the scatter of the next); then compounds 1 and 2 (each within the scatter of the next).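

In this assay, placing 4-cyanophenyl on the carbon with a double bond to nitrogen gives a number 1.39 log units lower from compound 1 to compound 4 (beyond the scatter) and likewise a number 1.39 log units lower from compound 2 to compound 4 (beyond the scatter) in the comparison with the other dichlorophenyl compound. The large drop is therefore no longer seen with 4-nitrophenyl alone but also with a second group that carries no chlorine. Cyano in place of nitro on an aromatic carbon gives a number 0.25 log units higher from compound 3 to compound 4 (within the scatter), so these two groups cannot be told apart in this assay, and nothing available gives a reason for any of these steps.

On these data alone, what remains open is where a phenyl ring carrying an amine or a carboxylic acid at this place would fall. As far as these compounds go, it is also open whether a phenyl ring with a single chlorine would stand with compound 1 or with compound 4.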